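The source may report more compounds than this note shows. Statements on the series, on what has been measured and on what is new or still open speak of the compounds shown alone.

In a toxicity assay on A549 cells (Homo sapiens) for cytotoxicity, read by luminescence and CellTiter-Glo, with a stated time of 48 h (on this read-out higher numbers stand for lower toxicity in this test and lower numbers for higher toxicity in this test), the measured compounds are:

Compound 1 `CC(C)(C)CC(C)(C)Nc1nc2ncccn2c1-c1ccc(Br)cc1`: > 100000 nM
Compound 2 `O=C(O)CCCOc1ccc(-c2nc3ncccn3c2NC2CCCCC2)cc1`: > 100000 nM

Both entries are limits of the assay, not numbers. Compound 2 therefore has no exact position, and the two compounds share one place: the limit of > 100000 nM in this assay, at which 2 of the 2 values shown sit.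

Compound 3 `Fc1ccc(COc2ccc(-c3nc4ncccn4c3NC3CCCCC3)cc2)cc1` keeps the core of compound 2 and changes one part: 4-fluorophenyl in place of 2-carboxyethyl on a saturated chain carbon bound to an oxygen on an aromatic ring. In words, 4-fluorophenyl takes the place of 2-carboxyethyl on a saturated chain carbon bound to an oxygen on an aromatic ring. Read one bond further out, 3-carboxypropyl becomes 4-fluorobenzyl.

Going by the values given here, no measured pair shows what this kind of change does in this assay, so any forecast is tentative. The step expected an at least 1.4-fold lower number from compound 2 to compound 3 (0.15 log units; that floor lies within the scatter) is small, leaning toward lower numbers, and another reading at the limit is quite possible.

For compound 3, the estimated value is 70000 nM, with an expected range from 20000 nM to 100000 nM.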

Compound 3, half-maximal cytotoxic concentration: 24000 nM
Beside the measured number, compound 3's estimate is 2.9-fold (0.46 log units) above it; low and high end bracket the measured number.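

In this assay, the place on a saturated chain carbon bound to an oxygen on an aromatic ring is the first shown where a change moves the read-out off the limit: 4-fluorophenyl in place of 2-carboxyethyl gives an at least 4.1-fold lower number from compound 2 to compound 3 (0.61 log units; beyond the scatter). Cut one bond further out, this is 3-carboxypropyl becoming 4-fluorobenzyl, and the lower number stands for higher toxicity. The step gives only a floor, and compound 3 alone carries an exact number, while the other two compounds are limits of the assay that share one place: the limit of > 100000 nM in this assay, at which 2 of the 3 values shown sit.

This single change removes the carboxylic acid and brings in the fluorinated aromatic ring together, so the compounds shown do not separate the two. Also open, as far as these compounds go, is what a plain benzyl without the fluorine, or an amine at the end of the chain, would read in this assay.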